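A few compounds are considered here, and "the series" means these few. Any claim that something is new, unique, unknown or untested is made for them only; others in the source may bear on it.

In this work compound 1 `Cc1ccc(-c2ccc(NC(=O)c3ccccc3)nc2)cc1` serves as the reference point. In an assay on isolated protein (Aquatica lateralis) for inhibition of Luciferin 4-monooxygenase (Luciola lateralis), read by a luciferase reporter, tested at 10 uM (on this read-out lower numbers stand for less inhibition and higher numbers for more inhibition at the one concentration tested (going by the name of the read-out)), compound 1 gives 51%. Compound 2 `CC(C)Oc1ccc(-c2ccc(NC(=O)c3ccccc3)nc2)cc1` carries isopropoxy in place of methyl on an aromatic carbon and in this assay compound 2 gives 38%. The step of a number 13 percentage points lower from compound 1 to compound 2 (beyond the scatter) is therefore the one measured example of this change among the compounds shown.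

Compound 3 `Cc1ccc(C(=O)Nc2ccc(-c3ccccc3)cn2)cc1` is built on a different core from compound 1; the two share the same atoms joined differently, and the difference between the two cores is not broken down here. In this assay compound 3 gives 18%, the lowest of the three numbers, standing beyond the scatter below both compound 2 and compound 1.

Compound 4 `CC(C)Oc1ccc(C(=O)Nc2ccc(-c3ccccc3)cn2)cc1` has not yet been measured. It differs from compound 3 by isopropoxy in place of methyl on an aromatic carbon, and since the place is described in the same words as for the change from compound 1 to compound 2, this is the same change made on the core of compound 3. Because the step of a number 13 percentage points lower from compound 1 to compound 2 (beyond the scatter) lowered inhibition by a modest amount, the step from compound 3 to compound 4 is expected to fall in the same direction, about a number 10 percentage points lower from compound 3 to compound 4 (within the scatter), though compound 3 already sits low, so the room to fall is limited. Compound 4 is therefore estimated at 8% in this assay, within a range from -5% to 22%, pending the measurement.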

Compound 4, a percentage reported as inhibition, at one concentration (the size of the read-out at that concentration, not a potency): 12%
Compound 4: the middle estimate sits 4 percentage points below what was measured; the measured number falls inside the stated range.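

In this assay, for the compounds shown here, isopropoxy in place of methyl on an aromatic carbon, made on the core of compound 3, gives a number 6 percentage points lower from compound 3 to compound 4 (within the scatter), so on this core the change produces no step that stands clear of the usual scatter. Set beside the earlier step, the result on this core cannot be told apart from the result on the core of compound 1: the same change on two cores in this assay, a number 13 percentage points lower (beyond the scatter) from compound 1 to compound 2 and a number 6 percentage points lower (within the scatter) from compound 3 to compound 4, 7 percentage points apart, within the scatter of two such steps The two steps are thus compatible with one shared effect of the change on both cores, but they do not show that its size carries over, as only one of them lies beyond the scatter, and two pairs say nothing about any further core in this series.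

The compounds shown leave open how other groups at the same place, para to a large group, would read on either core, for example an amine, a carboxylic acid or a longer chain on the oxygen. Also open, on these data alone, is whether the step between the two groups would look the same across a range of concentrations, as each number here is a single reading at one concentration and not a potency.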